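Nitro for bromo on the benzylthio arm

The source may report more compounds than this note shows. Statements on the series, on what has been measured and on what is new or still open speak of the compounds shown alone.

Compound 3 `Nc1nc(SCc2ccc(Br)cc2)c2ncn([C@@H]3O[C@H](CO)[C@@H](O)[C@H]3O)c2n1` gives 813 nM in an assay on isolated protein for binding affinity to Equilibrative nucleoside transporter 1 (Homo sapiens) (a higher number here means a weaker inhibitor, a lower number a stronger inhibitor), the lowest number of the three measured. Compound 1 `O=[N+]([O-])c1cccc2c1CCN(c1ncnc3c1ncn3[C@@H]1O[C@H](CO)[C@@H](O)[C@H]1O)C2` gives 3020 nM in this assay, and compound 2 `Cc1cccc(CSc2ncnc3c2ncn3[C@@H]2O[C@H](CO)[C@@H](O)[C@H]2O)c1` gives 12000 nM; both gaps to compound 3 lie beyond the scatter, so compound 3 is the strongest inhibitor of the three. Compound 4 `Nc1nc(SCc2ccccc2[N+](=O)[O-])c2ncn([C@@H]3O[C@H](CO)[C@@H](O)[C@H]3O)c2n1` has not yet been measured. It differs from compound 3 in one place: 2-nitrophenyl in place of 4-bromophenyl on a saturated chain carbon bound to a sulfur. Among the measured compounds shown here, no measured pair shows this change on its own, so the direction rests on nothing firmer than the spread of the three numbers. A small loss of affinity, near the edge of the scatter, is expected as the step of a 1.8-fold higher number from compound 3 to compound 4 (0.27 log units; within the scatter). Compound 4 is estimated at 1500 nM, within a range from 400 nM to 6000 nM.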

Compound 4, half-maximal inhibitory concentration: 4570 nM
Estimate against measurement, compound 4: 3.0-fold (0.48 log units) below; measured number inside the range.
By their numbers in this assay, from the lowest: compound 3; then compounds 1 and 4 (each within the scatter of the next); then compound 2.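

In this assay, 2-nitrophenyl in place of 4-bromophenyl on a saturated chain carbon bound to a sulfur gives a 5.6-fold higher number from compound 3 to compound 4 (0.75 log units; beyond the scatter). Among the compounds shown here, this is the only single-place step, and it shows that affinity at this position depends on the aryl group, with 4-bromobenzyl ahead of 2-nitrobenzyl. Nothing available explains the loss.

The step changes the substituent and its numbered ring position together, so their contributions cannot be separated. On these data alone, how an amine or carboxylic acid on the phenyl ring, or a longer chain in place of the saturated chain carbon, would fare remains open.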